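Adding a Methoxy Group to Compound 3

A few compounds are considered here, and "the series" means these few. Any claim that something is new, unique, unknown or untested is made for them only; others in the source may bear on it.

Measured in a functional assay on HepG2 cells (Homo sapiens) for cytotoxicity, read by MTT assay, with a stated time of 48 h; on this read-out lower numbers stand for stronger inhibition and higher numbers for weaker inhibition:

compound 1, `Fc1ccc2nc(-c3cccc(-c4nc5ccc(F)cc5[nH]4)c3)[nH]c2c1`, gives 17300 nM
compound 2, `Clc1ccc2nc(-c3cccc(-c4nc5ccc(Cl)cc5[nH]4)c3)[nH]c2c1`, gives 9100 nM
compound 3, `FC(F)(F)c1ccc2nc(-c3cccc(-c4nc5ccc(C(F)(F)F)cc5[nH]4)c3)[nH]c2c1`, gives 6600 nM

Compound 3 has the lowest of the three numbers in this assay. Its nearest neighbour is compound 2, whose number is higher by an amount that sits within the scatter of repeated measurements, so the two cannot be told apart on these data. The number for compound 1 lies further away, beyond the scatter, so compound 3 does stand apart from compound 1 in this assay, though not from compound 2.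

Compound 4, `COc1cc(-c2nc3ccc(C(F)(F)F)cc3[nH]2)cc(-c2nc3ccc(C(F)(F)F)cc3[nH]2)c1`, differs from compound 3 in one place: methoxy in place of hydrogen on an aromatic carbon. For the measured compounds named here, no measured pair in this set carries such a change, so there is no step on record to lean on. With nothing to suggest otherwise, the change is expected to move the number in this assay by no more than the scatter in either direction, that is, a step of a 1.1-fold lower number from compound 3 to compound 4 (0.04 log units; within the scatter) is expected.

Compound 4 is therefore expected to give about 6000 nM in this assay, with a likely range from 2500 nM to 15000 nM.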

Compound 4, half-maximal inhibitory concentration: 10700 nM
Compound 4: the middle estimate sits 1.8-fold (0.25 log units) below what was measured, and the stated range covers the measured number.
By their numbers in this assay, from the lowest: compounds 3, 2, 4 and 1 (each within the scatter of the next, the first and the last beyond it).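

Compounds 1, 2 and 3 all carry hydrogen on this aromatic carbon, so they could say nothing about what a substituent there would do; their differences lie elsewhere on the shared core. For the compounds shown here, compound 4 supplies the first reading for this position, meta to two large groups: methoxy in place of hydrogen comes with a 1.6-fold higher number from compound 3 to compound 4 (0.21 log units; within the scatter) in this assay, so on this single pair, placing this group on this carbon does not shift the number beyond what repeated measurements would scatter. Nothing at hand bears on what lies behind this result.

The compounds shown leave open whether this carbon would respond in the same way to a different group, such as an amine, a carboxylic acid or a longer chain in place of methoxy. They also leave open whether methoxy at this position would give a similar step on the fluoro compound 1 or the chloro compound 2, since it is seen here only with the trifluoromethyl groups of compound 3.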